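This account rests on a few compounds, and the source may have more. Where it says the series, first, only, none or still open, it means among the compounds named here.

Measured compounds in a functional assay on HEK293 cells for antagonist activity at transient receptor potential cation channel subfamily V member 1 (Homo sapiens), read by calcium flux; on this read-out higher numbers stand for weaker inhibition and lower numbers for stronger inhibition:

- compound 2 `Cc1nc(Nc2ccc(C(F)(F)F)c(Cl)c2)c2nc(Nc3c(Cl)cccc3Cl)sc2n1`: 3 nM
- compound 1 `O=C(O)c1ccc(Nc2ncnc3sc(Nc4c(Cl)cccc4Cl)nc23)cc1`: > 5000 nM (a limit of this assay, not a number)

For the measured compounds named here, compound 2 holds the only number given in this assay; the other value shown for the series is a limit. Compound 1 sits at the limit of > 5000 nM in this assay, at which 1 of the 2 values shown sits, in this assay, so nothing can be said about how far apart the two compounds lie beyond the fact that compound 1 reaches no number at all.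

Compound 3 `CS(=O)(=O)c1nc(Nc2ccc(C(F)(F)F)c(Cl)c2)c2nc(Nc3c(Cl)cccc3Cl)sc2n1` is the next member to be tested. It differs from compound 2 by methylsulfonyl in place of methyl on an aromatic carbon. Going by the values given here, no pair of measured compounds shares this change, so there is no measured step to lean on. Against that background the step from compound 2 to compound 3 in this assay is expected to be a modest loss, a 6.7-fold higher number from compound 2 to compound 3 (0.82 log units; beyond the scatter), going somewhat beyond the scatter but not far. Compound 3 is therefore estimated at 20 nM in this assay, with a plausible range from 3 nM to 200 nM.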

Compound 3, half-maximal inhibitory concentration: 274 nM
Estimate against measurement, compound 3: 14-fold (1.14 log units) below, outside the stated range (above it).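

In this assay, the aromatic carbon between two ring nitrogen atoms turns out to be sensitive to the group it carries: methylsulfonyl in place of methyl gives a 91-fold higher number from compound 2 to compound 3 (1.96 log units; beyond the scatter). For the compounds shown here, this is the first measured step at this position, and it shows that the position does not tolerate every group equally, although compound 3 still gives a real number of 274 nM and not a limit of the assay. Nothing measured here gives a cause for this step.

On these data alone, a single change cannot show whether the loss follows the added heavy atoms, the sulfur or the two hydrogen-bond acceptors that enter with methylsulfonyl, so the reason for the step remains open. As far as these compounds go, it also remains open how the read-out would respond at this same carbon to a hydrogen, an amine or a methoxy group, and whether methyl sits near the best this position can give or is itself open to improvement.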